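The source may hold more compounds than are shown below. What is called first, only, known or untested is meant among the compounds shown, and "the series" means these compounds.

Compound 3 `Cc1ccc(NC2=CC(=O)c3c(nc4n3[C@H]3OC[C@@H](O)[C@H]3OC4)C2=O)cc1` is one of three compounds from a shared core that have been tested. In a functional assay on ECa-109 cells for inhibition, with ECa-109 cell line (Homo sapiens) as the target, read by sulforhodamine B assay (a lower number here means a stronger inhibitor, a higher number a weaker inhibitor), compound 3 gives > 4000 nM, which is a limit of the assay and not a number. Compound 1 `CCCc1ccc(NC2=CC(=O)c3c(nc4n3[C@H]3OC[C@@H](O)[C@H]3OC4)C2=O)cc1` gives > 4000 nM in this assay, again a limit. Compound 2 `O=C1C(NC2CCCC2)=CC(=O)c2c1nc1n2[C@H]2OC[C@@H](O)[C@H]2OC1` gives > 16000 nM in this assay, also a limit. So compound 3 stands at the limit of > 4000 nM in this assay, at which 2 of the 3 values shown sit, and none of the three is resolved as a number.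

Compound 4 `O=C1C(Nc2ccccc2)=CC(=O)c2c1nc1n2[C@H]2OC[C@@H](O)[C@H]2OC1` has not been measured. It differs from compound 3 by hydrogen in place of methyl on an aromatic carbon.

The closest measured steps are a step that the two limits leave unreadable from compound 1 to compound 3, a step that the two limits leave unreadable from compound 2 to compound 3 and a step that the two limits leave unreadable from compound 1 to compound 2; all three are left unreadable by the limits, so none gives a size to lean on. The change to compound 4 is small, and every neighbouring compound sits at a limit, so no step beyond the scatter is expected in this assay. The estimate for compound 4 is therefore 8000 nM, within 2500 nM to 30000 nM, an expected step that the limit leaves unreadable from compound 3 to compound 4, most likely reported again as a limit.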

Compound 4, half-maximal inhibitory concentration: 3560 nM
Compound 4: middle estimate off by 2.2-fold (0.35 log units), on the high side; low and high end bracket the measured number.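

Among these compounds, compound 4, with hydrogen in place of methyl on an aromatic carbon para to a large group, is the first compound here to give a resolved number in this assay. Its two aryl neighbours give an at least 1.1-fold lower number from compound 3 to compound 4 (0.05 log units; that floor lies within the scatter) and an at least 1.1-fold lower number from compound 1 to compound 4 (0.05 log units; that floor lies within the scatter), so these steps are only floors and do not show whether removing the methyl or propyl group has a real effect. The clearer reading concerns the group on the amine nitrogen, where phenyl in place of cyclopentyl gives an at least 4.4-fold lower number from compound 2 to compound 4 (0.65 log units; beyond the scatter), but nothing measured here explains that step.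

On these data alone, how far the methyl group of compound 3 or the propyl group of compound 1 moves the number stays open: both compounds are held only at limits. Also open, as far as these compounds go, is how a methoxy group or a carboxylic acid on that same aromatic carbon would read in this assay.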